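A few compounds are considered here, and "the series" means these few. Any claim that something is new, unique, unknown or untested is made for them only; others in the source may bear on it.

Measured compounds:
- compound 1, `O=C(CCCCCc1ccc(F)c(Cl)c1)N1CCOC1=O`, giving 26 nM
- compound 2, `COc1cccc(CCCCCC(=O)N2CCOC2=O)c1`, giving 16300 nM
- compound 3, `O=C(CCCCCc1ccc(Cl)cc1)N1CCOC1=O`, giving 4600 nM

All three share one core and differ only in the groups on the aromatic ring at the far end. In an assay on HEK293 cells for inhibition of N-acylethanolamine-hydrolyzing acid amidase (Rattus norvegicus), read by LC-MS, with a stated time of 30 min (on this read-out lower numbers stand for stronger inhibition and higher numbers for weaker inhibition), compound 3 gives 4600 nM, the second highest of the three numbers. Its nearest neighbour is compound 2 with 16300 nM, a higher number beyond the scatter; compound 1 with 26 nM lies far below it. Compound 1 and compound 2 each differ from compound 3 in more than one place, so no single change can be read from those pairs.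

The next compound, compound 4, `CSc1ccc(CCCCCC(=O)N2CCOC2=O)cc1`, changes one thing: methylsulfanyl in place of chloro on an aromatic carbon. Among the compounds with values here, no measured pair shows the effect of exchanging these two groups, so the expectation rests on compound 3 alone. The step of a 1.2-fold lower number from compound 3 to compound 4 (0.06 log units; within the scatter) is estimated to stay within the usual scatter, with no clear direction. Compound 4 is therefore expected to give about 4000 nM, with a range from 1000 nM to 15000 nM.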

Compound 4, half-maximal inhibitory concentration: > 20000 nM
Compound 4 was reported as a limit; the forecaster's own chance of this, stated with the estimate: 10%; middle value at least 5.0-fold (0.69 log units) away from the limit.
By their numbers in this assay, from the lowest: compound 1; then compound 3; then compound 2. At a limit, above all of these: compound 4.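

Within the data shown here, this is the first single change that can be read: with methylsulfanyl in place of chloro on an aromatic carbon, para to a large group, this assay shows an at least 4.3-fold higher number from compound 3 to compound 4 (0.63 log units; beyond the scatter). The two groups are therefore not interchangeable at this position, even though the change only swaps a chlorine for a sulfur and a carbon. Compound 4 sits at a limit of the assay, not at a number: the limit of > 20000 nM in this assay, at which 1 of the 4 values shown sits.

The compounds shown leave open how large the step really is, and what a fluoro, a methyl or a methoxy group would give at this same position. It also remains open which part of the substitution on compound 1 accounts for its far lower number, as compound 1 differs from compound 3 in more than one place.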